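Changing the ring on a thiocarbonyl carbon

The source may hold more compounds than are shown below. What is called first, only, known or untested is meant among the compounds shown, and "the series" means these compounds.

In a functional assay on MCF7 cells (Homo sapiens) for inhibition, read by MTT assay, with stated times of 18 h and 4 h (on this read-out lower numbers stand for stronger inhibition and higher numbers for weaker inhibition), compound 2 `CCCCCCCCCCOP(=O)(O)OCCSC(=S)N1CCCC1` gives 70000 nM, and compound 1 `CCCCCCCCCCOP(=O)(O)OCCSC(=S)N1CCCCCC1` gives 43300 nM. Among the compounds with values here, these are the only two numbers so far. They lie within the scatter of each other, so compound 2 holds no firm rank. Compound 3 `CCCCCCCCCCOP(=O)(O)OCCSC(=S)N1CCCCC1` has not yet been measured in this assay. It differs from compound 2 as follows: piperidin-1-yl in place of pyrrolidin-1-yl on a thiocarbonyl carbon. Piperidin-1-yl thus stands in place of pyrrolidin-1-yl on a thiocarbonyl carbon. Within the data shown here, one measured step bears on this exchange: a 1.6-fold higher number from compound 1 to compound 2 (0.21 log units; within the scatter). That single step, also a ring exchange on a thiocarbonyl carbon, stayed within the scatter, so no change beyond the scatter is expected here. The expected step is a 1.3-fold lower number from compound 2 to compound 3 (0.10 log units; within the scatter). For compound 3 the estimated value is 55000 nM, with an expected range of 28000 nM to 100000 nM.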

Compound 3, half-maximal inhibitory concentration: 7240 nM
Estimate against measurement, compound 3: 7.6-fold (0.88 log units) above; measured number outside the range, below it.
By their numbers in this assay, from the lowest: compound 3; then compounds 1 and 2 (each within the scatter of the next).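

In this assay, the ring on the thiocarbonyl carbon proved to matter after all: piperidin-1-yl in place of pyrrolidin-1-yl gives a 9.7-fold lower number from compound 2 to compound 3 (0.99 log units; beyond the scatter), and piperidin-1-yl in place of azepan-1-yl gives a 6.0-fold lower number from compound 1 to compound 3 (0.78 log units; beyond the scatter). The earlier step had suggested that this position tolerates ring exchange, but that holds only for the pair of pyrrolidin-1-yl and azepan-1-yl, and among these three compounds the number does not follow ring size in one direction, since piperidin-1-yl alone stands apart, with a lower number than both. Nothing available explains this difference.

The compounds shown leave open whether a ring with a second hetero atom, such as morpholin-4-yl or piperazin-1-yl, would keep the low number of compound 3. They also leave open how an open-chain group such as diethylamino would compare on the same carbon.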